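The source may report more compounds than this note shows. Statements on the series, on what has been measured and on what is new or still open speak of the compounds shown alone.

In a functional assay on 1321-N1 cells for agonist activity at Free fatty acid receptor 1 (Homo sapiens), read by calcium flux, with a stated time of 0.4 s (on this read-out lower numbers stand for smaller maximal responses and higher numbers for larger maximal responses), compound 1 `C/C=C\C#Cc1ccc(CCC(=O)O)c(F)c1` gives 91%, compound 2 `C/C=C/C#Cc1ccc(CCC(=O)O)c(F)c1` gives 97%, and compound 3 `C/C(C#Cc1ccc(CCC(=O)O)c(F)c1)=C/CO` gives 105%. Compound 3 gives the highest of the three numbers, but its gap to compound 2 lies within the scatter, while a number 14 percentage points higher from compound 1 to compound 3 (beyond the scatter) lies beyond it. The step of a number 6 percentage points higher from compound 1 to compound 2 (within the scatter) rests on (the fact that compounds 1 and 2 differ only in the configuration as drawn). Compound 4 `C=C(C)C#Cc1ccc(CCC(=O)O)c(F)c1` is not yet measured; the change is 1-methylethenyl in place of 3-hydroxy-1-methylprop-1-en-1-yl on a triple-bonded carbon. Among the compounds with values here, the steps that bear on it, a number 8 percentage points higher from compound 2 to compound 3 (within the scatter) and a number 14 percentage points higher from compound 1 to compound 3 (beyond the scatter), run the other way, with the same group entering. Removing it is therefore expected to cost a little or nothing beyond the scatter, estimated as a number 10 percentage points lower from compound 3 to compound 4 (within the scatter). Compound 4 is expected to give 95% in this assay, within 80% to 108%.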

Compound 4, largest response reached (reported as efficacy), in percent of the reference or control that the assay uses: 106%
Beside the measured number, compound 4's estimate is 11 percentage points below it, within the range that was stated.
By their numbers in this assay, from the lowest: compounds 1, 2, 3 and 4 (each within the scatter of the next, the first and the last beyond it).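

In this assay, the response holds when 1-methylethenyl replaces 3-hydroxy-1-methylprop-1-en-1-yl on the triple-bonded carbon, with a number 1 percentage points higher from compound 3 to compound 4 (within the scatter), so the hydrogen-bond donor and acceptor counted in the leaving group are not required for this maximal response here. The same group in place of prop-1-en-1-yl gives a number 9 percentage points higher from compound 2 to compound 4 (within the scatter) but a number 15 percentage points higher from compound 1 to compound 4 (beyond the scatter), so whether that change clears the scatter depends on the starting compound: the fact that compounds 1 and 2 differ only in the configuration as drawn

Open, going by these compounds, is whether an amine, a carboxylic acid or a longer chain on this triple-bonded carbon would keep the response. Maximal response alone also leaves potency across the series unresolved.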